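This account rests on a few compounds, and the source may have more. Where it says the series, first, only, none or still open, it means among the compounds named here.

Measured so far in a functional assay on HeLa cells (Homo sapiens) for antiproliferative activity, read by MTT assay, with a stated time of 72 h; on this read-out higher numbers stand for weaker inhibition and lower numbers for stronger inhibition
compound 1 `CC(C)/C=C/C(=O)Nc1cccc(Oc2nc(Nc3ccn(C)n3)nc3c2CSCC3)c1` gives 40100 nM as a number
compound 2 `C=C(C)C(=O)Nc1cccc(Oc2nc(Nc3ccn(C)n3)nc3c2CSCC3)c1` gives > 50000 nM as a limit

Among the measured compounds shown here, compound 1 holds the only number, since compound 2 reports only a limit. Compound 3 `COc1cccc(Nc2nc3c(c(Oc4cccc(NC(=O)/C=C/C(C)C)c4)n2)CSCC3)c1` keeps the core of compound 1 and changes one group (3-methoxyphenyl in place of 1-methyl-1H-pyrazol-3-yl on a nitrogen on an aromatic ring). For the measured compounds named here, the one measured step (an at least 1.2-fold higher number from compound 1 to compound 2 (0.09 log units; that floor lies within the scatter)) lies on a carbonyl carbon, not at this place, and gives no size for this change. In this assay no step beyond the scatter is therefore expected (a 1.6-fold lower number from compound 1 to compound 3 (0.21 log units; within the scatter)). The expected value for compound 3 is 25000 nM with an estimated range from 7000 nM to 50000 nM.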

Compound 3, half-maximal inhibitory concentration: > 50000 nM
Compound 3 gave a limit, no number; the forecaster's own chance of this, stated with the estimate: 30%; middle value at least 2.0-fold (0.30 log units) away from the limit.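

Among the compounds shown here, the first reading at this nitrogen in this assay is an at least 1.2-fold higher number from compound 1 to compound 3 (0.09 log units; that floor lies within the scatter) for 3-methoxyphenyl in place of 1-methyl-1H-pyrazol-3-yl. Compound 3 gives > 50000 nM as a limit and not a number. The full size of this change cannot be read because the value stops at that limit: the limit of > 50000 nM in this assay, at which 2 of the 3 values shown sit.

Open, as far as these compounds go, is whether an unsubstituted phenyl or a pyridine ring on this nitrogen would give a number in this assay at all. Also open, from the compounds shown here alone, is whether any group here moves the value beyond the scatter from compound 1.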